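A few compounds are considered here, and "the series" means these few. Any claim that something is new, unique, unknown or untested is made for them only; others in the source may bear on it.

Measured compounds in the series:

Compound 1 `Cc1cc(C(=O)O)ccc1C(C)N1CCC[C@H](O[C@H](CO)c2cc(Cl)cc(Cl)c2)[C@@H]1c1ccccc1` — 18000 nM
Compound 2 `Cc1cc(C(=O)O)ccc1CN1CCC[C@H](O[C@H](CO)c2ccnc(Cl)c2)[C@@H]1c1ccccc1` — 50000 nM

Both values come from an assay on isolated protein for activation of cGMP-dependent protein kinase 1 (Homo sapiens), read by ADP-Glo, with stated times of 30 min and 2 h, in the presence of a further agent that is not named here; a higher number here means that more compound is needed for the effect, a lower number that less compound is needed. Compound 1 gives 18000 nM and stands lowest of the two numbers; compound 2 gives 50000 nM, a higher number by a margin that lies beyond the usual scatter. Compound 2 also differs from compound 1 in more than one place, so no single change can be read off from that pair.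

Compound 3 `Nc1cc(C(=O)O)ccc1CN1CCC[C@H](O[C@H](CO)c2cc(Cl)cc(Cl)c2)[C@@H]1c1ccccc1` has not yet been measured. Compared with compound 1, the change is a group of 11 heavy atoms (8 carbon, 1 nitrogen, 2 oxygen; one six-membered aromatic ring of carbon only) in place of a group of 12 heavy atoms (10 carbon, 2 oxygen; one six-membered aromatic ring of carbon only), on an amine nitrogen in a ring: the entering 2-amino-4-carboxybenzyl group carries more hydrogen-bond donors and acceptors than the group it replaces, and the site of the change, on the amine nitrogen in a ring of the shared core, is the same one that varies between compound 1 and compound 2.

Among the compounds with values here, with no single-change pair measured, the direction of the step cannot be anchored. The expected step from compound 1 to compound 3 is a 1.4-fold higher number from compound 1 to compound 3 (0.14 log units; within the scatter), a modest move toward a higher number with wide uncertainty. The estimated value for compound 3 in this assay is 25000 nM, ranging from 8000 nM to 80000 nM.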

Compound 3, half-maximal effective concentration: 290 nM
Compound 3: middle estimate off by 86-fold (1.94 log units), on the high side, and the stated range ends above it.
By their numbers in this assay, from the lowest: compound 3; then compound 1; then compound 2.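

On an amine nitrogen in a ring of the shared core, the substituent strongly affects the number in this assay: replacing the group of 12 heavy atoms with 2-amino-4-carboxybenzyl gives a 62-fold lower number from compound 1 to compound 3 (1.79 log units; beyond the scatter). Within the data shown here, the earlier pair differed in more than one place, so this is the first step that can be assigned to this one site, and it shows that a large shift is possible there while the 1-(3,5-dichlorophenyl)-2-hydroxyethoxy group and the phenyl group stay unchanged. No measurement at hand explains the size of this step.

The exchange itself alters the substituent at more than one atom, so the compounds shown do not separate the contribution of the amino group from that of the other differences between the entering and leaving groups. Also open, on these data alone, is whether the step depends on the amino group specifically or would persist with a hydroxyl group or a methylamino group in its place on the 2-amino-4-carboxybenzyl group.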